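The source may hold more compounds than are shown below. What is called first, only, known or untested is meant among the compounds shown, and "the series" means these compounds.

Measured compounds in an ADME assay on L6 cells (Rattus norvegicus) for cytotoxicity, read by resazurin assay, with a stated time of 72 h; a higher number here means a weaker inhibitor, a lower number a stronger inhibitor:
- compound 1 `CN(C)C12CC(c3ccccc3)C(CN(C(=O)CN3CCCC3)C1)C(c1ccccc1)C2`: 12600 nM
- compound 2 `CN(C)C12CC(c3ccccc3)C(CN(CCN3CCCC3)C1)C(c1ccccc1)C2`: 5580 nM

Compound 1 stands at the highest of the two numbers in this assay. Its nearest neighbour is compound 2, and the change between them gives a 2.3-fold lower number from compound 1 to compound 2 (0.35 log units; beyond the scatter), a modest step with the 2-(pyrrolidin-1-yl)ethyl group in place of the ((pyrrolidin-1-yl)methyl)carbonyl group on the amine nitrogen in the ring.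

Compound 3 `CN(C)C12CC(c3ccccc3)C(CN(CCCN3CCCCC3)C1)C(c1ccccc1)C2` has not yet been measured. It differs from compound 1 as follows: 3-(piperidin-1-yl)propyl in place of ((pyrrolidin-1-yl)methyl)carbonyl on an amine nitrogen in a ring. Among the compounds with values here, the one measured step that bears on this change is the one from compound 1 to compound 2, since it too removes the ((pyrrolidin-1-yl)methyl)carbonyl group from the same ring nitrogen and puts a basic-nitrogen-bearing chain there; that step was a 2.3-fold lower number from compound 1 to compound 2 (0.35 log units; beyond the scatter). Because of a 2.3-fold lower number from compound 1 to compound 2 (0.35 log units; beyond the scatter), a step of similar size and in the same direction is expected for compound 3, namely a 2.1-fold lower number from compound 1 to compound 3 (0.32 log units; beyond the scatter). Compound 3 is therefore estimated at 6000 nM in this assay, with a range from 2800 nM to 13000 nM.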

Compound 3, half-maximal inhibitory concentration: 1750 nM
Compound 3: middle estimate off by 3.4-fold (0.54 log units), on the high side; the whole stated range lies above it.
By their numbers in this assay, from the lowest: compound 3; then compound 2; then compound 1.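

In (this assay) the ring nitrogen that carries the side chain responds to more than the removal of the ((pyrrolidin-1-yl)methyl)carbonyl group: the 3-(piperidin-1-yl)propyl group gives a larger step (a 7.2-fold lower number from compound 1 to compound 3 (0.86 log units; beyond the scatter)) than the one seen earlier with 2-(pyrrolidin-1-yl)ethyl (a 2.3-fold lower number from compound 1 to compound 2 (0.35 log units; beyond the scatter)). The two side chains without a carbonyl also differ from each other (a 3.2-fold lower number from compound 2 to compound 3 (0.50 log units; beyond the scatter)), so the number at this position is not set by the loss of the carbonyl alone, and it moves further down with the (piperidin-1-yl)methyl in place of pyrrolidin-1-yl change at the chain carbon. Nothing measured here accounts for the size of these steps.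

That last step changes the chain and the ring together, so the compounds shown cannot say how much belongs to the longer chain and how much to the six-membered ring; a 3-(pyrrolidin-1-yl)propyl or a 2-(piperidin-1-yl)ethyl group would separate the two. Going by these compounds, whether a still longer chain, or a morpholine in place of the piperidine, would carry the number further in the same direction also remains open.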